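Swapping the Ethylcarbamoyl for a Methyl Ester

This account rests on a few compounds, and the source may have more. Where it says the series, first, only, none or still open, it means among the compounds named here.

Compounds measured so far:
Compound 1, `Cc1cn([C@@H]2O[C@H](CO[Si](C)(C)C(C)(C)C)[C@@]3(OS(=O)(=O)C=C3NCC(=O)C(=O)O)[C@H]2O[Si](C)(C)C(C)(C)C)c(=O)n(C)c1=O`, in a functional assay on HEL cells (Homo sapiens) for cytotoxicity, read by microscopy (a higher number here means that more compound is tolerated, a lower number that less compound is tolerated), compound 1 gives 400000 nM.
Compound 2, `CCNC(=O)NC1=CS(=O)(=O)O[C@@]12[C@@H](CO[Si](C)(C)C(C)(C)C)O[C@@H](n1cc(C)c(=O)n(C)c1=O)[C@@H]2O[Si](C)(C)C(C)(C)C`, in this assay compound 2 gives only a limit, >= 3200 nM.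

Compound 2 therefore stands on a limit rather than a number in this assay, and its tolerated concentration is not pinned down. For the measured compounds named here, the only measured step between neighbours is a step that the limit leaves unreadable from compound 1 to compound 2, which the limit of compound 2 makes unreadable; the evidence for it is just (the limit of >= 3200 nM in this assay, at which 1 of the 2 values shown sits).

Compound 3, `COC(=O)CCNC1=CS(=O)(=O)O[C@@]12[C@@H](CO[Si](C)(C)C(C)(C)C)O[C@@H](n1cc(C)c(=O)n(C)c1=O)[C@@H]2O[Si](C)(C)C(C)(C)C`, is not yet measured. It differs from compound 2 in one place: 2-(methoxycarbonyl)ethyl in place of ethylcarbamoyl on an amine nitrogen. No measured step involves a 2-(methoxycarbonyl)ethyl group, so nothing shown bears directly on this change, and no direction can be read from the data. The expected step that the limit leaves unreadable from compound 2 to compound 3 is thus wide and uncertain. Compound 3 is estimated at 100000 nM in this assay, within a range from 3200 nM to 400000 nM, with a real chance that only a limit is reported again.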

Compound 3, minimum cytotoxic concentration: >= 400000 nM
Compound 3: only a limit was reported; the forecaster's own chance of this, stated with the estimate: 40%; at least 4.0-fold (0.60 log units) between middle value and limit.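

In this assay compound 3 gives >= 400000 nM, which is a limit and not a number. Set against the only exact value shown, this gives a number no lower from compound 1 to compound 3 (the limit leaves the size open), so with the 2-(methoxycarbonyl)ethyl group on the amine nitrogen, the tolerated concentration does not fall below that of compound 1. The size of this step and of the step from compound 2 to compound 3 cannot be read, so no order can be given for compound 2 and compound 3 and no size can be given for the effect of the change.

The compounds shown leave open how much compound is tolerated with the 2-(methoxycarbonyl)ethyl group, since only a limit stands for it. They also leave open whether a carboxylic acid in place of the methyl ester on this chain, or a longer chain ending in the same methyl ester, would give an exact number in this assay.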